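Swapping a dimethoxyphenyl for a trifluoromethoxyphenyl cap

The source may hold more compounds than are shown below. What is called first, only, known or untested is meant among the compounds shown, and "the series" means these compounds.

Compound 1 `COc1ccc(C(=O)c2cc(OC)c(OC)c(OC)c2)cc1NC(=O)/C=C/c1ccc(OC)c(OC)c1`: 10200 nM
Compound 2 `COc1ccc(/C=C/C(=O)Nc2cc(C(=O)c3cc(OC)c(OC)c(OC)c3)ccc2OC)cc1`: 12800 nM
Compound 3 `COc1cccc(/C=C/C(=O)Nc2cc(C(=O)c3cc(OC)c(OC)c(OC)c3)ccc2OC)c1`: 6200 nM

In a functional assay on DU-145 cells (Homo sapiens) for cytotoxicity, read by MTT assay, with a stated time of 72 h (a lower number here means a stronger inhibitor, a higher number a weaker inhibitor), compound 1 gives 10200 nM, the second highest of the three numbers. Compound 4 `COc1ccc(C(=O)c2cc(OC)c(OC)c(OC)c2)cc1NC(=O)/C=C/c1cccc(OC(F)(F)F)c1` differs from it by 3-(trifluoromethoxy)phenyl in place of 3,4-dimethoxyphenyl on a double-bonded chain carbon bound to a double-bonded chain carbon. Among the compounds with values here, two measured steps bear on this. Removing the same methoxy gave a 1.6-fold lower number from compound 1 to compound 3 (0.22 log units; within the scatter), and moving the remaining methoxy from the 4-position to the 3-position gave a 2.1-fold lower number from compound 2 to compound 3 (0.31 log units; beyond the scatter), while a 1.3-fold higher number from compound 1 to compound 2 (0.10 log units; within the scatter). Within the data shown here, no measured pair shows methoxy exchanged for trifluoromethoxy, so that part is untested. A small step to a lower number, or none beyond the scatter, is therefore expected: from compound 1 to compound 4 the estimate is a 1.5-fold lower number from compound 1 to compound 4 (0.16 log units; within the scatter). Compound 4 is expected to give about 7000 nM, in the range 2500 nM to 20000 nM.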

Compound 4, half-maximal inhibitory concentration: 10200 nM
Estimate against measurement, compound 4: 1.5-fold (0.16 log units) below; the measured number falls inside the stated range.
By their numbers in this assay, from the lowest: compounds 3, 1, 4 and 2 (each within the scatter of the next, the first and the last beyond it).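

In this assay, 3-(trifluoromethoxy)phenyl in place of 3,4-dimethoxyphenyl gave no change at the digits printed from compound 1 to compound 4 (within the scatter) and so left the number where it stood. Trifluoromethyl in place of methyl on the oxygen, the first such exchange among these compounds, gave a 1.6-fold higher number from compound 3 to compound 4 (0.22 log units; within the scatter) and the step from the 4-methoxyphenyl cap gave a 1.3-fold lower number from compound 2 to compound 4 (0.10 log units; within the scatter) so fluorine on this cap moved nothing beyond the scatter. No measured evidence explains why these caps read alike.

Open, going by these compounds, is whether a cap bearing an amine or a carboxylic acid would shift the number beyond the scatter. Also open, on these data alone, is whether trifluoromethoxy at the 4-position would read like compound 4.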